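The compounds below may be only part of what the source reports. "The series", "measured", "known", "first", "only" and "open" are said of these compounds alone.

In a physicochemical assay for solubility, in phosphate buffer, with a stated time of 18 h, at pH 7 (on this read-out higher numbers stand for higher solubility and lower numbers for lower solubility), compound 2 `CC(C)CN1C(=O)c2ccccc2[C@H](C(=O)Nc2ccc(F)c(C#N)c2)[C@H]1c1ccco1` gives 13000 nM, the lowest of the three numbers here. Compound 1 `CC(=O)N1CCCC([C@@H]2[C@@H](C(=O)Nc3ccc(F)c(C#N)c3)c3ccccc3C(=O)N2CC(C)C)C1` gives 69000 nM and compound 3 `CC(C)CN1C(=O)c2ccccc2[C@H](C(=O)Nc2ccc(F)c(C#N)c2)[C@H]1c1cccnc1` gives 55000 nM. Compound 4 `CC(C)CN1C(=O)c2ccccc2[C@H](C(=O)Nc2ccc(F)c(C#N)c2)[C@H]1c1ccncc1` differs from compound 2 in one place: pyridin-4-yl in place of furan-2-yl on a saturated ring carbon. The step that bears most directly on this change is a 4.2-fold higher number from compound 2 to compound 3 (0.63 log units; beyond the scatter), where pyridin-3-yl replaced the same furan-2-yl, a modest rise beyond the scatter. The step of a 1.3-fold lower number from compound 1 to compound 3 (0.10 log units; within the scatter) shows that pyridin-3-yl and 1-acetylpiperidin-3-yl lie within the scatter of each other. A rise of similar size is therefore expected in this assay for compound 4, namely a 3.8-fold higher number from compound 2 to compound 4 (0.59 log units; beyond the scatter). Compound 4 is estimated at 50000 nM, with a range from 20000 nM to 130000 nM.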

Compound 4, solubility: 55000 nM
For compound 4 the middle estimate is 1.1-fold (0.04 log units) below the measured one; the measured number falls inside the stated range.
By their numbers in this assay, from the lowest: compound 2; then compounds 3, 4 and 1 (each within the scatter of the next).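

In this assay, pyridin-4-yl in place of furan-2-yl gives a 4.2-fold higher number from compound 2 to compound 4 (0.63 log units; beyond the scatter), so the rise seen earlier with pyridin-3-yl is not confined to that one pyridine. Exchanging the two pyridines gives no change at the digits printed from compound 3 to compound 4 (within the scatter), and the step to pyridin-4-yl from 1-acetylpiperidin-3-yl is a 1.3-fold lower number from compound 1 to compound 4 (0.10 log units; within the scatter). Among these four compounds, only compound 2, with furan-2-yl, stands apart from the rest.

Nothing here explains why furan-2-yl differs. As far as these compounds go, whether a primary amine or a carboxylic acid on this ring carbon would stay level with the pyridines remains open.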